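Working notes on the step to compound 4

The source may report more compounds than this note shows. Statements on the series, on what has been measured and on what is new or still open speak of the compounds shown alone.

Values in a functional assay on B16 cells (Mus musculus) for cytotoxicity, read by MTT assay, with a stated time of 48 h; on this read-out lower numbers stand for stronger inhibition and higher numbers for weaker inhibition:
- compound 1 `C#CC(=O)Nc1ccc(C#C)cc1`: 6300 nM
- compound 2 `C#CCNC(=O)c1cn(Cc2ccccc2)nn1`: 65000 nM
- compound 3 `C#CCNC(=O)c1cn(CC(=O)OCc2ccccc2)nn1`: > 100000 nM (a limit)

Compound 2 gives 65000 nM, the higher of the two actual numbers. Compound 1 lies lower at 6300 nM, a gap beyond the scatter. Compound 3 has no number, and its > 100000 nM is a limit of the assay.

Compound 4 `C#CCNC(=O)c1cn(CCOC(C)=O)nn1` carries acetoxymethyl in place of phenyl on a saturated chain carbon bound to an aromatic nitrogen. Among the compounds with values here, no measured pair isolates this change, so the expectation rests on compound 2 at 65000 nM as the closest number. No step beyond the scatter is expected in this assay. The expected step is a 1.2-fold higher number from compound 2 to compound 4 (0.09 log units; within the scatter). A result reported only as a limit remains possible for compound 4 because of the limit of > 100000 nM in this assay, at which 1 of the 3 values shown sits. For compound 4 the estimated value is 80000 nM, with an expected range of 30000 nM to 200000 nM.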

Compound 4, half-maximal inhibitory concentration: > 100000 nM
Compound 4: no number, only a limit; the forecaster's own chance of this, stated with the estimate: 40%; middle value at least 1.2-fold (0.09 log units) away from the limit.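

In this assay compound 4 stands at > 100000 nM, which is a limit and not a number. Acetoxymethyl in place of phenyl on a saturated chain carbon bound to an aromatic nitrogen gives an at least 1.5-fold higher number from compound 2 to compound 4 (0.18 log units; that floor lies within the scatter), the first step in the series that can be read at this place; it shows no gain from losing the aromatic ring, and since only a floor is available, its true size stays unknown. The limit now accounts for a larger share of the series: the limit of > 100000 nM in this assay, at which 2 of the 4 values shown sit.

As far as these compounds go, whether an amine or a carboxylic acid on the same saturated chain would give a measurable number in this assay stays open. From the compounds shown here alone, it also stays open whether a longer chain ending in phenyl would move the value of compound 2 from 65000 nM.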